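Carboxy to propylcarbamoyl at the limit of a cytotoxicity assay

A few compounds are considered here, and "the series" means these few. Any claim that something is new, unique, unknown or untested is made for them only; others in the source may bear on it.

In an ADME assay on SH-SY5Y cells (Homo sapiens) for cytotoxicity, read by MTT assay, with a stated time of 48 h (a lower number here means a stronger inhibitor, a higher number a weaker inhibitor), compound 1 (`COc1ccc(C(=O)/C=C/c2ccc(C(=O)O)cc2)c(O)c1`) gives > 100000 nM as its reading, which is a limit and not a number. Compound 2 (`CCOCCCOc1ccc(/C=C/C(=O)c2ccc(OC)cc2O)cc1OC`) gives > 100000 nM as a limit too. Compound 3 (`CCOCCOc1cccc(/C=C/C(=O)c2ccc(OC)cc2O)c1`) also gives > 100000 nM as a limit. No measured number therefore places compound 1 more exactly, and it stands level with the other two at the same limit (the limit of > 100000 nM in this assay, at which 3 of the 3 values shown sit).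

Compound 4 (`CCCNC(=O)c1ccc(/C=C/C(=O)c2ccc(OC)cc2O)cc1`) has propylamino in place of hydroxy on a carbonyl carbon, which turns the carboxy of compound 1 into propylcarbamoyl. Going by the values given here, no measured step between compounds that differ in one place is available, so the expectation rests only on compound 1, compound 2 and compound 3 sharing that limit (the limit of > 100000 nM in this assay, at which 3 of the 3 values shown sit). The estimated step of a number no higher from compound 1 to compound 4 (the limit leaves the size open) is expected to stay within the scatter, in neither direction. For compound 4 the estimated value is 100000 nM (expected range 40000 nM to 200000 nM).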

Compound 4, half-maximal inhibitory concentration: > 100000 nM
Compound 4: no number, only a limit (the forecaster's own chance of this, stated with the estimate: 70%); the middle value lies on the limit itself.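

Compound 1 and compound 4 both read as limits, not numbers, in this assay, so no step between them can be read: the limit of > 100000 nM in this assay, at which 4 of the 4 values shown sit.

The compounds shown leave open whether propylcarbamoyl in place of carboxy changes the reading in this assay at all.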